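A few compounds are considered here, and "the series" means these few. Any claim that something is new, unique, unknown or untested is made for them only; others in the source may bear on it.

Measured so far in an ADME assay on RAW264.7 cells (Mus musculus) for cytotoxicity, read by MTT assay, with a stated time of 24 h, in the presence of a further agent that is not named here; on this read-out higher numbers stand for weaker inhibition and lower numbers for stronger inhibition (each entry is a limit and not a number):

Compound 1 `O=C1OC(Cc2nc(-c3ccccc3)no2)c2ccccc21` gives > 40000 nM as a limit
Compound 2 `O=C1OC(Cc2nc(Cc3ccccc3)no2)c2ccccc21` gives > 40000 nM as a limit
Compound 3 `COCCOc1ccc(C(O)C2OC(=O)c3c(OC)cc(OC)cc32)cc1` gives > 40000 nM as a limit

Compound 3 therefore has no exact place on the scale, and it stands on the limit of > 40000 nM in this assay, at which 3 of the 3 values shown sit, together with the other two, so the three cannot be ranked.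

Compound 4 `COc1cc(OC)c2c(c1)C(C(O)c1ccc(OCc3ccc(Cl)cc3)cc1)OC2=O` keeps the core of compound 3 and alters one side chain (in words, (4-chlorophenyl in place of methoxymethyl on a saturated chain carbon bound to an oxygen on an aromatic ring)). Cut one bond further out, 2-methoxyethoxy gives way to (4-chlorobenzyl)oxy.

Among the measured compounds shown here, only one measured step exists, a step that the two limits leave unreadable from compound 1 to compound 2 in the data. It also brings in a benzyl group, but on another core, and its size cannot be read, so it offers no number to carry over.

The expectation therefore rests on compound 3 and its limit of > 40000 nM in this assay alone. No step beyond the usual scatter is expected, and the data favour no direction, so the estimated step reads a number no higher from compound 3 to compound 4 (the limit leaves the size open) in this forecast.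

Compound 4 is expected at 40000 nM within an estimated range of 15000 nM to 80000 nM. A limit rather than an exact number is a likely outcome for compound 4 as well.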

Compound 4, half-maximal inhibitory concentration: > 40000 nM
Compound 4 ended at the assay's limit; the forecaster's own chance of this, stated with the estimate: 70%; the middle value lies on the limit itself.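

Compound 3 and compound 4 both end at a limit of this assay and not at an exact number, so no step between them can be read: the limit of > 40000 nM in this assay, at which 4 of the 4 values shown sit.

The compounds shown leave open whether 4-chlorophenyl in place of methoxymethyl changes the read-out at all, as none of them gives an exact value on this scale.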